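Biaryl carbamates: sulfamoyl in place of the distal phenyl

The compounds below may be only part of what the source reports. "The series", "measured", "known", "first", "only" and "open" are said of these compounds alone.

Measured in an assay on cell membranes for binding affinity to Fatty-acid amide hydrolase 1 (Rattus norvegicus) (a higher number here means a weaker inhibitor, a lower number a stronger inhibitor), so far:
compound 1, `O=C(NC1CCCCC1)Oc1cccc(-c2ccc(F)cc2)c1`: 65 nM
compound 2, `O=C(NC1CCCCC1)Oc1cccc(-c2cccc(Oc3ccccc3)c2)c1`: 420 nM
compound 3, `O=C(NC1CCCCC1)Oc1cccc(-c2cccc(-c3ccccc3)c2)c1`: 565 nM

Compound 3 stands at the highest of the three numbers. Its nearest neighbour is compound 2: the step of a 1.3-fold higher number from compound 2 to compound 3 (0.13 log units; within the scatter) is within the scatter, so the two cannot be ordered. Compound 1 is furthest away, with a number well below that of compound 3 and beyond the scatter.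

Compound 4, `NS(=O)(=O)c1cccc(-c2cccc(OC(=O)NC3CCCCC3)c2)c1`, differs from compound 3 by sulfamoyl in place of phenyl on an aromatic carbon. Among the measured compounds shown here, no measured step covers an exchange of this kind. For the measured compounds named here, the one step at this carbon, a 1.3-fold higher number from compound 2 to compound 3 (0.13 log units; within the scatter), swapped one large group for another and changed little. Where compound 3 carries phenyl, compound 1 carries fluorine, and compound 1 gives 65 nM, the only hint that a smaller substituent at this carbon goes with a lower number; that hint rests on a single compound.

On that basis compound 4 is expected to land below compound 3, with the step of a 3.8-fold lower number from compound 3 to compound 4 (0.58 log units; beyond the scatter) estimated as modest and the range kept wide. The estimate for compound 4 is 150 nM, between 40 nM and 600 nM.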

Compound 4, half-maximal inhibitory concentration: 26.5 nM
For compound 4 the middle estimate is 5.7-fold (0.75 log units) above the measured one, and the stated range ends above it.
By their numbers in this assay, from the lowest: compound 4; then compound 1; then compounds 2 and 3 (each within the scatter of the next).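

In this assay this aromatic carbon turns out to be far from indifferent to its substituent: the earlier phenoxy-to-phenyl exchange stayed within the scatter, whereas sulfamoyl in place of phenyl gives a 21-fold lower number from compound 3 to compound 4 (1.33 log units; beyond the scatter), and sulfamoyl in place of phenoxy gives a 16-fold lower number from compound 2 to compound 4 (1.20 log units; beyond the scatter). A large group carrying a ring is therefore not needed at this carbon, meta to a large group, for a low number in this series. The exchange alters the heavy-atom count, the ring and the hydrogen-bond donors and acceptors all at once, and no evidence is available to separate these changes or explain the drop.

Open, as far as these compounds go, is how methylsulfonyl, a carboxamide or a carboxylic acid would compare with sulfamoyl at this carbon. Equally open, from the compounds shown here alone, is whether a small amine would give a similar number.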